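Fluoro in Place of Hydrogen: From Compound 3 to Compound 4

A few compounds are considered here, and "the series" means these few. Any claim that something is new, unique, unknown or untested is made for them only; others in the source may bear on it.

Measured in a functional assay on HT-29 cells (Homo sapiens) for inhibition, read by MTT assay, with a stated time of 48 h; a higher number here means a weaker inhibitor, a lower number a stronger inhibitor:
- compound 1, `COc1cc(/C=C/c2ccc(NC(=O)/C=C/c3cc(OC)c(OC)c(OC)c3)cc2)cc(OC)c1`, gives 1820 nM
- compound 2, `COc1cc(/C=C/c2ccc(NC(=O)/C=C/c3ccc(C(F)(F)F)cc3)cc2)cc(OC)c1`, gives 1780 nM
- compound 3, `COc1cc(/C=C/c2ccc(OC(=O)/C=C/c3ccccc3)cc2)cc(OC)c1`, gives 9050 nM

Compound 3 has the highest number of the three in this assay, which makes it the weakest inhibitor; compounds 1 and 2 both sit lower by gaps beyond the usual scatter. Compound 4, `COc1cc(/C=C/c2ccc(OC(=O)/C=C/c3ccc(F)cc3)cc2)cc(OC)c1`, differs from compound 3 by a single change: fluoro in place of hydrogen on an aromatic carbon. Among the measured compounds, swapping a trimethoxy pattern for a trifluoromethyl on the same ring (compound 1 against compound 2) left the numbers within the scatter, so a small fluoro on that ring is expected to move little. Compound 4 is estimated at 8000 nM, within 3000 nM to 20000 nM, an expected step of a 1.1-fold lower number from compound 3 to compound 4 (0.05 log units; within the scatter) that stays inside the scatter.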

Compound 4, half-maximal inhibitory concentration: 7770 nM
The estimate for compound 4 lay 1.0-fold (0.01 log units) above the measured number; the range from low to high includes it.
By their numbers in this assay, from the lowest: compounds 2 and 1 (each within the scatter of the next); then compounds 4 and 3 (each within the scatter of the next).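

In this assay, fluoro on the aromatic carbon para to a large group gives a 1.2-fold lower number from compound 3 to compound 4 (0.07 log units; within the scatter). Going by these compounds alone, this is the first comparison here in which only one place differs, and in this assay hydrogen and fluoro at this position cannot be told apart. No measurement shown bears on the reason for this result. From the compounds shown here alone, whether an amine or a carboxylic acid on this same carbon would shift the number remains open. So does whether fluoro would give a similar step on a compound with the amide link of compound 2.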